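The source may report more compounds than this note shows. Statements on the series, on what has been measured and on what is new or still open speak of the compounds shown alone.

Measured so far:
compound 1, `Oc1cc(C(F)(F)F)ccc1-c1nc(-c2ccccc2O)n(-c2ccccc2Cl)n1`: 102%
compound 2, `Oc1cc(C(F)(F)F)ccc1-c1nc(-c2ccccc2O)n(-c2ccccc2C(F)(F)F)n1`: 92.2%
compound 3, `Oc1cc(C(F)(F)F)ccc1-c1nc(-c2ccccc2O)n(-c2cccc(Cl)c2)n1`: 100%

All three values come from a functional assay on PC-12 cells (Rattus norvegicus) for cytotoxicity, read by MTT assay, with stated times of 2 h and 24 h, tested at 10 uM; a lower number here means a weaker effect, a higher number a stronger effect of the compound at the concentration tested. Compound 4, `Oc1cc(C(F)(F)F)ccc1-c1nc(-c2ccccc2O)n(-c2cccc(C(F)(F)F)c2)n1`, has not yet been measured there. It differs from compound 3 by trifluoromethyl in place of chloro on an aromatic carbon. The same kind of change was made once before, from compound 1 to compound 2, namely (trifluoromethyl in place of chloro on an aromatic carbon), and that step was a number 9.8 percentage points lower from compound 1 to compound 2 (within the scatter). The two cores are not identical: compound 1 and compound 3 differ by 3-chlorophenyl in place of 2-chlorophenyl on an aromatic nitrogen, so that in compound 1 the changed group sits ortho to a large group, while in compound 3 it sits meta to a large group. Compound 4 is therefore expected to show a step of a number 8 percentage points lower from compound 3 to compound 4 (within the scatter), which rests on the earlier a number 9.8 percentage points lower from compound 1 to compound 2 (within the scatter) being small. For compound 4 the estimated read-out in this assay is 92%, with an expected range from 78% to 104%.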

Compound 4, a percentage reported as activity, at one concentration (the size of the read-out at that concentration, not a potency): 99.9%
Estimate against measurement, compound 4: 7.9 percentage points below; measured number inside the range.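

In this assay, trifluoromethyl in place of chloro gives a number 0.1 percentage points lower from compound 3 to compound 4 (within the scatter), and beside its earlier use on the other core the change looks the same on both: the same change on two cores in this assay, a number 9.8 percentage points lower (within the scatter) from compound 1 to compound 2 and a number 0.1 percentage points lower (within the scatter) from compound 3 to compound 4, 9.7 percentage points apart, within the scatter of two such steps

The two remaining new steps, which swap the phenyl group on the aromatic nitrogen, read alike, with a number 7.7 percentage points higher from compound 2 to compound 4 (within the scatter) and a number 2.1 percentage points lower from compound 1 to compound 4 (within the scatter). This shows that the change stays within the scatter on these two cores at the one concentration tested, but it does not show that a larger effect would carry over, or that the result holds on any other core.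

The compounds shown leave open what an amine or a carboxylic acid in place of chloro on the phenyl group would do to this read-out.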